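Amide nitrogen substituents at the cytotoxicity limit

The source may report more compounds than this note shows. Statements on the series, on what has been measured and on what is new or still open speak of the compounds shown alone.

Measured in a functional assay on A549 cells (Homo sapiens) for cytotoxicity, read by MTT assay, with a stated time of 48 h; on this read-out higher numbers stand for weaker inhibition and lower numbers for stronger inhibition:
- compound 1 `NC(=O)CC[C@H](NS(=O)(=O)c1ccc([N+](=O)[O-])cc1)C(=O)O`: > 500000 nM (a limit)
- compound 2 `CNC(=O)CC[C@H](NS(=O)(=O)c1ccc([N+](=O)[O-])cc1)C(=O)O`: > 500000 nM (a limit)
- compound 3 `CC(C)NC(=O)CC[C@H](NS(=O)(=O)c1ccc([N+](=O)[O-])cc1)C(=O)O`: > 500000 nM (a limit)

Compound 3 has only a limit, > 500000 nM, and no number. Going by the values given here, the series so far sits at the limit of > 500000 nM in this assay, at which 3 of the 3 values shown sit, so compound 3 cannot be ordered against compound 1 or compound 2.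

The next structure is compound 4 `CCCCNC(=O)CC[C@H](NS(=O)(=O)c1ccc([N+](=O)[O-])cc1)C(=O)O`. The change is butyl in place of isopropyl on an amide-type nitrogen.

Three measured steps changed the same nitrogen: a step that the two limits leave unreadable from compound 1 to compound 2, a step that the two limits leave unreadable from compound 1 to compound 3 and a step that the two limits leave unreadable from compound 2 to compound 3. None has a readable size, so they supply no number to carry over. All three compounds nevertheless remain at the limit in this assay, so no shift in either direction is expected. The estimated step is expected to be a number no higher from compound 3 to compound 4 (the limit leaves the size open).

A further limit is the likeliest report. Compound 4 is estimated at 500000 nM, with an expected range from 200000 nM to 800000 nM.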

Compound 4, half-maximal inhibitory concentration: 276000 nM
For compound 4 the middle estimate is 1.8-fold (0.26 log units) above the measured one; the measured number falls inside the stated range.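

Going by these compounds alone, compound 4, with butyl on the amide-type nitrogen, is the first to give a number rather than a limit in this assay. That number gives three readings, each only a floor: an at least 1.8-fold lower number from compound 3 to compound 4 (0.25 log units; that floor lies within the scatter), an at least 1.8-fold lower number from compound 2 to compound 4 (0.25 log units; that floor lies within the scatter) and an at least 1.8-fold lower number from compound 1 to compound 4 (0.25 log units; that floor lies within the scatter). The steps among compound 1, compound 2 and compound 3 still cannot be read, and the rest of the series stays at the limit: the limit of > 500000 nM in this assay, at which 3 of the 4 values shown sit.

On these data alone, the true size of the steps to compound 4 stays open, since only their floors can be read. As far as these compounds go, it also remains open whether a longer chain such as hexyl or octyl, or a chain ending in an amine or a carboxylic acid, on the same nitrogen would move the number further from that limit.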